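The source may hold more compounds than are shown below. What is called first, only, known or untested is meant among the compounds shown, and "the series" means these compounds.

Working notes on the series. Compound 3 `COc1cccc(C(C)Sc2nc3c(cnn3C)c(=O)n2-c2ccccc2)c1` is one of three analogues sharing a core that differ only in the group on the sulfur. In an assay on isolated protein for inhibition of Retinaldehyde dehydrogenase 3 (Homo sapiens) (a lower number here means a stronger inhibitor, a higher number a weaker inhibitor), compound 3 gives 174 nM, compound 2 `CCC(Sc1nc2c(cnn2C)c(=O)n1-c1ccccc1)c1ccccc1` gives 119 nM and compound 1 `CC(Sc1nc2c(cnn2C)c(=O)n1-c1ccccc1)c1ccccn1` gives 89 nM. The two measured steps, a 1.3-fold higher number from compound 1 to compound 2 (0.13 log units; within the scatter) and a 2.0-fold higher number from compound 1 to compound 3 (0.29 log units; within the scatter), both lie within the scatter, so the three compounds are not separated by these numbers and compound 3 cannot be set apart from the other two.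

Compound 4 `CC(Sc1nc2c(cnn2C)c(=O)n1-c1ccccc1)c1cccc(O)c1` differs from compound 3 by hydrogen in place of methyl on an oxygen on an aromatic ring. Within the data shown here, no measured step bears directly on this change: both steps replace the whole aromatic group on the chain carbon, and neither touches a substituent on such a ring. Both were within the scatter, which gives no reason to expect a large effect from a smaller change at the ring edge, though the data on the methoxy itself are silent. The expected step is a 1.0-fold lower number from compound 3 to compound 4 (0.01 log units; within the scatter), none beyond the scatter. Compound 4 is therefore estimated at 170 nM, with a range from 70 nM to 420 nM in this assay.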

Compound 4, half-maximal inhibitory concentration: 91 nM
Compound 4: the middle estimate sits 1.9-fold (0.27 log units) above what was measured; the range from low to high includes it.
By their numbers in this assay, from the lowest: compounds 1, 4, 2 and 3 (each within the scatter of the next).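

In this assay, among these compounds, hydrogen in place of methyl on an oxygen on an aromatic ring gives a 1.9-fold lower number from compound 3 to compound 4 (0.28 log units; within the scatter) and so, like the earlier replacements of the whole aromatic group, stays within the scatter; this is the first reading of a change to a substituent on that ring. Against the other groups on the sulfur, 3-hydroxyphenyl gives a 1.3-fold lower number from compound 2 to compound 4 (0.12 log units; within the scatter) and a 1.0-fold higher number from compound 1 to compound 4 (0.01 log units; within the scatter) and is not separated from either, so the four compounds still form one unresolved set. No evidence is at hand that bears on this methoxy to hydroxy result.

As far as these compounds go, whether an amine or a carboxylic acid in place of the hydroxy on this ring would reach beyond the scatter remains open. So does the effect of a longer chain on the same oxygen.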